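From chloro to fluoro on the bromo compound

This account rests on a few compounds, and the source may have more. Where it says the series, first, only, none or still open, it means among the compounds named here.

Compound 1 `CCOC(=O)c1c(-c2cccc(-c3ccccc3)c2)[nH]c2cc(OC)c(Cl)cc2c1=O`: > 21500 nM, a limit
Compound 2 `CCOC(=O)c1c(-c2cccc(Oc3ccccc3)c2)[nH]c2cc(OC)c(Cl)cc2c1=O`: > 21500 nM, a limit
Compound 3 `CCOC(=O)c1c(-c2cccc(Br)c2)[nH]c2cc(OC)c(Cl)cc2c1=O`: > 21500 nM, a limit

All three entries come from an ADME assay on BJ cells (Homo sapiens) for cytotoxicity, read by luminescence, with a stated time of 72 h (on this read-out lower numbers stand for an effect already at smaller amounts and higher numbers for an effect only at larger amounts of compound), and each is a limit rather than a number. Compound 3 has no number of its own here, only (the limit of > 21500 nM in this assay, at which 3 of the 3 values shown sit).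

The next compound is compound 4 `CCOC(=O)c1c(-c2cccc(Br)c2)[nH]c2cc(OC)c(F)cc2c1=O`, and it carries a single structural change: fluoro in place of chloro on an aromatic carbon. In words, fluoro takes the place of chloro on an aromatic carbon, ortho to a methoxy group, and the rest of the molecule stays the same.

For the measured compounds named here, none of the measured steps changes this chloro. They concern a different group, which is phenyl, phenoxy or bromo in turn. They are a step that the two limits leave unreadable from compound 1 to compound 2, a step that the two limits leave unreadable from compound 1 to compound 3 and a step that the two limits leave unreadable from compound 2 to compound 3. None of them has a readable size, so they offer no measured effect to carry over to the new change.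

The expectation therefore rests on compound 3, whose entry is > 21500 nM, a limit. In this assay, no step beyond the scatter is expected, and another limit is the likeliest report. The expected step is a step that the limit leaves unreadable from compound 3 to compound 4. The estimate for compound 4 is 22000 nM, with an expected range of 11000 nM to 45000 nM.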

Compound 4, half-maximal effective concentration: > 21500 nM
Compound 4: no number, only a limit; the forecaster's own chance of this, stated with the estimate: 85%; the middle value is on the limit's open side.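

In this assay, compound 3 and compound 4 are each reported only as a limit, so the change from chloro to fluoro has no readable size. All the compounds shown share that same entry: the limit of > 21500 nM in this assay, at which 4 of the 4 values shown sit.

The compounds shown leave open at what amount any of them would give an effect, and whether chloro and fluoro differ at all.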